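The source may hold more compounds than are shown below. What is called first, only, known or untested is meant among the compounds shown, and "the series" means these compounds.

Compound 1 `Oc1cccc(C(Nc2ccccn2)c2ccc3cccnc3c2O)c1Cl` is the starting point of this account. In an assay for inhibition of protein disulfide-isomerase (Homo sapiens), with a stated time of 1 h (on this read-out higher numbers stand for weaker inhibition and lower numbers for stronger inhibition), compound 1 gives 370 nM, the highest of the two plain numbers available. The closest comparison is compound 2 `Cc1ccnc(NC(c2ccc(F)cc2)c2ccc3cccnc3c2O)c1`, which in this assay gives 140 nM, a number lower than that of compound 1 by a margin beyond the usual scatter. Compound 3 `Cc1ccnc(NC(c2ccccc2C)c2ccc3cccnc3c2O)c1` reaches only a limit in this assay, > 40000 nM, and is therefore not a number. That limit is recorded as the limit of > 40000 nM in this assay, at which 1 of the 3 values shown sits.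

The change under consideration is 4-ethylphenyl in place of 2-chloro-3-hydroxyphenyl on a saturated chain carbon bound to an aromatic carbon and a nitrogen on an aromatic ring, giving compound 4 `CCc1ccc(C(Nc2ccccn2)c2ccc3cccnc3c2O)cc1`. Among the compounds with values here, the only measured step at the same place is an at least 280-fold higher number from compound 2 to compound 3 (2.45 log units; beyond the scatter), where a 2-methylphenyl replaced a 4-fluorophenyl. The change leading to compound 4 goes the other way around: a phenyl bearing substituents at the 2- and 3-positions gives way to a 4-ethylphenyl, closer in pattern to the 4-fluorophenyl of compound 2, the stronger of the two measured numbers. On that basis the number for compound 4 is expected to fall somewhat below that of compound 1, with the step of a 1.9-fold lower number from compound 1 to compound 4 (0.27 log units; within the scatter) estimated as modest and possibly within the scatter. Compound 4 is thus estimated at 200 nM, within a range from 60 nM to 700 nM.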

Compound 4, half-maximal inhibitory concentration: 170 nM
Estimate against measurement, compound 4: 1.2-fold (0.07 log units) above, and the stated range covers the measured number.
By their numbers in this assay, from the lowest: compounds 2 and 4 (each within the scatter of the next); then compound 1. At a limit, above all of these: compound 3.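

In this assay the position on the saturated chain carbon does not depend on the hydroxy and chloro substituents of the group that leaves: the step is a 2.2-fold lower number from compound 1 to compound 4 (0.34 log units; beyond the scatter), and the group that enters is 4-ethylphenyl, with 8 carbon atoms, 0 hydrogen-bond donors and 0 hydrogen-bond acceptors. Of the two steps shown at this place, an at least 280-fold higher number from compound 2 to compound 3 (2.45 log units; beyond the scatter) is large, whereas the new step is modest and runs the opposite way, so this position can carry a substituted phenyl group of more than one kind without a loss. Nothing measured among these compounds accounts for the lower number of compound 4.

The compounds shown leave open whether the chlorine or the hydroxy group of compound 1 on its own accounts for the step, and whether a 2-methylphenyl group would behave on the core of compound 4 as it does in compound 3. They also leave open how far the 4-position of this phenyl ring can be taken, for instance with a longer chain such as butyl, with an amine or with a carboxylic acid in place of the ethyl group.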